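The source may report more compounds than this note shows. Statements on the series, on what has been measured and on what is new or still open speak of the compounds shown alone.

Compound 1, `C=CCc1cc(OC)c(OC(C)C(OCC)c2ccc(O)c(OC)c2)c(OC)c1`: 332 nM
Compound 2, `C=CCc1cc(OC)c(O[C@H](C)[C@H](OCC)c2ccc(O)c(OC)c2)c(OC)c1`: 583 nM

Both compounds were tested in an assay on HEK293 cells for agonist activity at transient receptor potential cation channel subfamily M member 8 (Homo sapiens), read by fluorescence and calcium flux, with a stated time of 5 min; on this read-out higher numbers stand for an effect only at larger amounts of compound and lower numbers for an effect already at smaller amounts. Compound 2 and compound 1 differ only in that compound 2 is drawn with both stereocentres fixed, and the step of a 1.8-fold higher number from compound 1 to compound 2 (0.24 log units; within the scatter) shows that this left the read-out within the scatter; the two numbers cannot be ordered against each other, a point that rests on (the fact that one of compounds 1 and 2 is drawn with a defined configuration and the other without, at the place where they differ).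

Compound 3, `C=CCc1cc(OC)c(O[C@@H](C)[C@H](OCC)c2ccc(O)c(OC)c2)c(OC)c1`, has not yet been measured. Relative to compound 2 the change is the two compounds have the same atoms and bonds and differ only in configuration as drawn: 1 of 2 stereo elements differ; a stereocentre at a saturated chain carbon is drawn R in compound 2 and S in compound 3. Among the compounds with values here, the only measured step, from compound 1 to compound 2, concerns drawn configuration and was within the scatter, so on that basis alone a move of a 1.0-fold higher number from compound 2 to compound 3 (0.01 log units; within the scatter) in this assay is expected, that is nothing beyond the scatter, though a single inverted centre is a different kind of change and leaves room for a larger shift. Compound 3 is therefore estimated at 600 nM, in the range 200 nM to 1800 nM.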

Compound 3, half-maximal effective concentration: 1130 nM
For compound 3 the middle estimate is 1.9-fold (0.27 log units) below the measured one; the measured number falls inside the stated range.
By their numbers in this assay, from the lowest: compounds 1, 2 and 3 (each within the scatter of the next, the first and the last beyond it).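

Within the data shown here, the step of a 1.9-fold higher number from compound 2 to compound 3 (0.29 log units; within the scatter) is the first comparison between two compounds with both stereocentres drawn, and in this assay it leaves them unordered, so inverting this one centre has no effect that can be told from the scatter: the fact that compounds 2 and 3 differ only in the configuration as drawn. Among these compounds, the step of a 3.4-fold higher number from compound 1 to compound 3 (0.53 log units; beyond the scatter) is the first in this set to lie beyond the scatter, although only modestly, so compound 3 needs larger amounts than compound 1 for its effect. That comparison sets a compound drawn without configuration against one with both centres fixed, so it cannot be assigned to either centre alone: the fact that one of compounds 1 and 3 is drawn with a defined configuration and the other without, at the place where they differ.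

On these data alone, the other possible combinations of configuration at the two stereocentres remain open. So does what a longer chain or an amine on the shared core would do to the read-out.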